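Ethyl to isopropyl: a change without direct precedent

A few compounds are considered here, and "the series" means these few. Any claim that something is new, unique, unknown or untested is made for them only; others in the source may bear on it.

In a functional assay (aorta) with Rattus norvegicus as the target (on this read-out higher numbers stand for weaker inhibition and lower numbers for stronger inhibition), compound 3 (`CCc1cn2ccccc2c1S(=O)(=O)c1ccc(OCCCNC(C)(C)C)cc1`) gives 413 nM and sits level with compound 1 (`CC(C)c1cn2ccccc2c1S(=O)(=O)c1ccc(OCCCN(C)C)cc1`) at 390 nM while compound 2 (`CCCCN(CCCC)CCCOc1ccc(S(=O)(=O)c2c(C(C)C)cn3ccccc23)cc1`) stands well lower at 21.6 nM on this read-out.

The change to compound 4 (`CC(C)c1cn2ccccc2c1S(=O)(=O)c1ccc(OCCCNC(C)(C)C)cc1`) is ethyl to isopropyl (methyl in place of hydrogen on a saturated chain carbon bound to an aromatic carbon and a saturated chain carbon) that is, methyl in place of hydrogen on a saturated chain carbon bound to an aromatic carbon and a saturated chain carbon.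

Going by the values given here, the one measured step (an 18-fold lower number from compound 1 to compound 2 (1.26 log units; beyond the scatter)) is large but concerns dibutylamino in place of dimethylamino, a different change, and gives no measure of this one.

No step beyond the scatter is therefore expected in this assay and the expected step is small (a 1.4-fold lower number from compound 3 to compound 4 (0.14 log units; within the scatter)).

For compound 4 the estimate is 300 nM with an expected range from 100 nM to 900 nM as a working figure.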

Compound 4, half-maximal inhibitory concentration: 41.8 nM
The estimate for compound 4 lay 7.2-fold (0.86 log units) above the measured number; the measured number lies below the stated range.
By their numbers in this assay, from the lowest: compounds 2 and 4 (each within the scatter of the next); then compounds 1 and 3 (each within the scatter of the next).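

In this assay, methyl in place of hydrogen on a saturated chain carbon bound to an aromatic carbon and a saturated chain carbon is a real gain on this shared core (a 9.9-fold lower number from compound 3 to compound 4 (0.99 log units; beyond the scatter)). With isopropyl held, (tert-butyl)amino in place of dimethylamino also counts (a 9.3-fold lower number from compound 1 to compound 4 (0.97 log units; beyond the scatter)), while (tert-butyl)amino in place of dibutylamino leaves the number level (a 1.9-fold higher number from compound 2 to compound 4 (0.29 log units; within the scatter)). No measurement at hand accounts for these steps.

Going by these compounds, whether the ethyl to isopropyl step keeps its size with dimethylamino or dibutylamino stays open. So does the effect of cyclopropyl or a longer chain in place of isopropyl.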